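The source may hold more compounds than are shown below. What is called first, only, known or untested is meant among the compounds shown, and "the series" means these compounds.

Compound 2 `CN(C)c1ccc2c(=O)c(C(=O)Nc3cc(F)cc(F)c3)cn(-c3ccc(OCCCCCCC[N+]4(C)CCCC4)c(Cl)c3)c2n1` stands lowest of the three measured compounds in an assay on LX2 cells for inhibition of COL1A1 promoter (Homo sapiens), read by a luciferase reporter, with a stated time of 24 h, tested at 50 uM (a higher number here means a stronger effect of the compound at the concentration tested, a lower number a weaker effect), where compound 2 gives 2.59%. Compound 1 `Cc1cc(-n2cc(C(=O)Nc3cc(F)cc(F)c3)c(=O)c3ccc(N(C)C)nc32)ccc1OCCCCCCC[N+]1(C)CCCC1` gives 35.9% in this assay, and compound 3 `CN1CC[N+](C)(CCCCCCCOc2cc(-n3cc(C(=O)Nc4cc(F)cc(F)c4)c(=O)c4ccc(N(C)C)nc43)ccc2Cl)CC1` gives 45.2%. Among the measured compounds shown here, the one measured single-point step, a number 33.3 percentage points lower from compound 1 to compound 2 (beyond the scatter), concerns a change on an aromatic carbon. Compound 4 `CC[N+]1(CCCCCCCOc2ccc(-n3cc(C(=O)Nc4cc(F)cc(F)c4)c(=O)c4ccc(N(C)C)nc43)cc2Cl)CCCC1` differs from compound 2 in another place: methyl in place of hydrogen on a saturated chain carbon bound to an amine nitrogen in a ring. For the measured compounds named here, no measured step touches the charged ring nitrogen or its chain carbon, so that one step gives no guide here, and the expected change in this assay is none beyond the scatter, though from so low a starting number only an upward move has room. Compound 4 is therefore estimated at 8%, between -5% and 30%, an expected step of a number 5.4 percentage points higher from compound 2 to compound 4 (within the scatter).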

Compound 4, a percentage reported as inhibition, at one concentration (the size of the read-out at that concentration, not a potency): 23.5%
Compound 4: the middle estimate sits 15.5 percentage points below what was measured; the range from low to high includes it.
By their numbers in this assay, from the lowest: compound 2; then compound 4; then compounds 1 and 3 (each within the scatter of the next).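

The position on a saturated chain carbon bound to an amine nitrogen in a ring had not been probed by any earlier step, and it proves responsive: in this assay, methyl to ethyl gives a number 20.9 percentage points higher from compound 2 to compound 4 (beyond the scatter). Thus, a change of only one carbon at this position can move the read-out beyond the scatter. Nothing available here explains this rise.

From the compounds shown here alone, whether a longer chain such as propyl would raise the number further remains open. So does whether methyl to ethyl would act the same way with methyl rather than chloro on the aromatic carbon.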